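This account rests on a few compounds, and the source may have more. Where it says the series, first, only, none or still open, it means among the compounds named here.

Measured compounds in the series:

- compound 1, `CC1(C)C(=O)N(c2ccc(SC(F)(F)F)cc2)C(=O)N1Cc1ccncc1` — < 0.02 ug/mL
- compound 2, `CC1(C)C(=O)N(c2ccc(SC(F)(F)F)cc2)C(=O)N1Cc1ccnc(C(=O)O)c1` — 0.142 ug/mL
- compound 3, `CC1(C)C(=O)N(c2ccc(SC(F)(F)F)cc2)C(=O)N1Cc1ccnc(NC2CCCCC2)c1` — < 0.025 ug/mL

In a physicochemical assay for solubility, read by nephelometry (on this read-out higher numbers stand for higher solubility and lower numbers for lower solubility), compound 3 gives < 0.025 ug/mL, which is a limit of the assay and not a number. Compound 1 likewise sits at a limit, < 0.02 ug/mL. Among the measured compounds shown here, compound 2 gives 0.142 ug/mL, the one number among the three. The measured steps read an at least 7.1-fold higher number from compound 1 to compound 2 (0.85 log units; beyond the scatter), an at least 5.6-fold lower number from compound 2 to compound 3 (0.75 log units; beyond the scatter) and a step that the two limits leave unreadable from compound 1 to compound 3; the last is blocked by the two limits the limit of < 0.02 ug/mL in this assay, at which 1 of the 3 values shown sits, and (the limit of < 0.025 ug/mL in this assay, at which 1 of the 3 values shown sits).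

Compound 4, `CNc1cc(CN2C(=O)N(c3ccc(SC(F)(F)F)cc3)C(=O)C2(C)C)ccn1`, differs from compound 3 by methyl in place of cyclohexyl on a nitrogen on an aromatic ring. For the measured compounds named here, no measured step makes this same change; the step from compound 1 to compound 3 is the nearest in kind, adding cyclohexylamino to hydrogen, and both its ends are limits, so it gives no readable size. Going by the values given here, the only change that moved this assay beyond the scatter was carboxy, which compound 4 lacks. A step of an at least 2.0-fold higher number from compound 3 to compound 4 (0.30 log units; that floor lies within the scatter) is therefore expected, small and uncertain, with a real chance that only a limit is reported. Compound 4 is estimated at 0.05 ug/mL, between 0.015 ug/mL and 0.2 ug/mL.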

Compound 4, solubility: 0.075 ug/mL
The estimate for compound 4 lay 1.5-fold (0.18 log units) below the measured number; the measured number falls inside the stated range.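

In this assay, methyl in place of cyclohexyl on a nitrogen on an aromatic ring gives an at least 3.0-fold higher number from compound 3 to compound 4 (0.47 log units; beyond the scatter), so the group on that nitrogen changes the read-out, and this floor is set by the limit of compound 3: the limit of < 0.025 ug/mL in this assay, at which 1 of the 4 values shown sits.

Methylamino in place of hydrogen on an aromatic carbon gives an at least 3.7-fold higher number from compound 1 to compound 4 (0.57 log units; beyond the scatter), the first step beyond the scatter from hydrogen with a group other than carboxy, and this floor is set by the limit of compound 1: the limit of < 0.02 ug/mL in this assay, at which 1 of the 4 values shown sits.

Methylamino in place of carboxy on an aromatic carbon gives a 1.9-fold lower number from compound 2 to compound 4 (0.28 log units; within the scatter), which leaves these two compounds unseparated.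

As far as these compounds go, how the read-out runs along a longer chain on that nitrogen, such as ethyl or propyl, stays open. So does where a primary amine or a hydroxyl on that aromatic carbon would stand against compound 4.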